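Furan-3-yl analogue: moving the hydroxyl on the pendant phenyl

The compounds below may be only part of what the source reports. "The series", "measured", "known", "first", "only" and "open" are said of these compounds alone.

Going by the values given here, compound 3 `Oc1cccc(-c2cc(-c3ccoc3)cc(-c3ccccc3O)n2)c1` gives 29.5% in an assay on isolated protein for inhibition of DNA topoisomerase 1 (Homo sapiens), with a stated time of 30 min, tested at 100 uM (a lower number here means a weaker effect, a higher number a stronger effect of the compound at the concentration tested), the lowest of the three numbers so far. Compound 2 `Oc1cccc(-c2cc(-c3ccsc3)cc(-c3cccc(O)c3)n2)c1` gives 59.2% in this assay, and compound 1 `Oc1cccc(-c2cc(-c3cccs3)cc(-c3cccc(O)c3)n2)c1` gives 91.7%; both gaps to compound 3 are beyond the scatter. Compound 4 `Oc1cccc(-c2cc(-c3ccoc3)cc(-c3cccc(O)c3)n2)c1` differs from compound 3 only at one place: 3-hydroxyphenyl in place of 2-hydroxyphenyl on an aromatic carbon. With this change compound 4 carries the same pair of 3-hydroxyphenyl groups as compounds 1 and 2. Among the compounds with values here, the single measured step, a number 32.5 percentage points lower from compound 1 to compound 2 (beyond the scatter), concerns the five-membered heteroaryl and not the hydroxyphenyl, so it does not bear directly on the present change; no measured pair isolates the shift of the hydroxyl from the 2- to the 3-position. What can be said is that both compounds bearing two 3-hydroxyphenyl groups sit higher in this assay than compound 3, though their heteroaryl also differs. An increase beyond the scatter, a number 20.5 percentage points higher from compound 3 to compound 4 (beyond the scatter), is therefore expected, with wide uncertainty. Compound 4 is estimated at 50%, within 25% to 75%.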

Compound 4, a percentage reported as inhibition, at one concentration (the size of the read-out at that concentration, not a potency): 44.2%
Beside the measured number, compound 4's estimate is 5.8 percentage points above it; the measured number falls inside the stated range.
By their numbers in this assay, from the lowest: compound 3; then compound 4; then compound 2; then compound 1.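

With furan-3-yl held fixed, the hydroxyl shift on the pendant phenyl now has a measured size in this assay, with a number 14.7 percentage points higher from compound 3 to compound 4 (beyond the scatter) for 3-hydroxyphenyl in place of 2-hydroxyphenyl at this place next to the ring nitrogen. With two 3-hydroxyphenyl groups held fixed, the five-membered heteroaryl can now be read across three members, with a number 15 percentage points lower from compound 2 to compound 4 (beyond the scatter) against thiophen-3-yl and a number 47.5 percentage points lower from compound 1 to compound 4 (beyond the scatter) against thiophen-2-yl, which puts furan-3-yl lowest of the three. Nothing at hand bears on the reason for any of these steps.

Open is whether the gain from 3-hydroxyphenyl carries over to the thiophen-2-yl and thiophen-3-yl compounds, given that the compounds shown pair 2-hydroxyphenyl only with furan-3-yl. Also open, from the compounds shown here alone, is how a 4-hydroxyphenyl, 3-methoxyphenyl or 3-aminophenyl group would read at this place.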